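This account rests on a few compounds, and the source may have more. Where it says the series, first, only, none or still open, it means among the compounds named here.

Measured compounds:
Compound 1, `N#CC1=C(N)Oc2c(N)cc3nc4ccccc4nc3c2C12C(=O)N(Cc1cnnn1-c1cccc(Br)c1)c1ccccc12`; in a functional assay on HepG2 cells (Homo sapiens) for antiproliferative activity, read by MTT assay, with a stated time of 48 h (on this read-out higher numbers stand for weaker inhibition and lower numbers for stronger inhibition), compound 1 gives > 50000 nM, which is a limit of the assay and not a number.
Compound 2, `Cc1ccc(-n2nncc2CN2C(=O)C3(C(C#N)=C(N)Oc4c(N)cc5nc6ccccc6nc5c43)c3ccccc32)cc1Cl`; in this assay compound 2 gives > 50000 nM, again a limit of the assay rather than a number.

Compound 2 therefore stands only at a limit in this assay, with no number to place it. Among the measured compounds shown here, the single measured step, a step that the two limits leave unreadable from compound 1 to compound 2, cannot be read, because the limit of > 50000 nM in this assay, at which 2 of the 2 values shown sit, shows both values resting at the same limit.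

Compound 3, `Cc1cc(C)c(-n2nncc2CN2C(=O)C3(C(C#N)=C(N)Oc4c(N)cc5nc6ccccc6nc5c43)c3ccccc32)c(C)c1`, differs from compound 2 by 2,4,6-trimethylphenyl in place of 3-chloro-4-methylphenyl on an aromatic nitrogen. The measured step from compound 1 to compound 2 bears on this change, since it also exchanged the phenyl group on that aromatic nitrogen, yet its size is unreadable. No reason within these two values points to compound 3 leaving the limit. Compound 3 is therefore expected to show, in this assay, a step that the limit leaves unreadable from compound 2 to compound 3, meaning no readable change. The estimate for compound 3 is 80000 nM, within a range from 30000 nM to 250000 nM, most likely reported only as a limit.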

Compound 3, half-maximal inhibitory concentration: 48100 nM
Beside the measured number, compound 3's estimate is 1.7-fold (0.22 log units) above it; low and high end bracket the measured number.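

In this assay, among the compounds shown here, compound 3 gives 48100 nM, the only true number among the three values, so a group on this aromatic nitrogen can give a reading inside the measurable range, though only just. The step is an at least 1.0-fold lower number from compound 2 to compound 3 (0.01 log units; that floor lies within the scatter), and the exchange for 3-bromophenyl is an at least 1.0-fold lower number from compound 1 to compound 3 (0.01 log units; that floor lies within the scatter); both are floors, so the real gaps could be larger, but nothing here shows that they are. These floors say so little because the other two compounds have no number of their own: the limit of > 50000 nM in this assay, at which 2 of the 3 values shown sit.

On these data alone, all three groups on this nitrogen are phenyl rings carrying only methyl, chlorine or bromine, so it remains open whether a different kind of group there, such as a phenyl ring bearing an amine or a carboxylic acid, or a plain alkyl chain, would bring the number clearly lower. As far as these compounds go, it also remains open whether all three methyl groups of 2,4,6-trimethylphenyl are needed for a reading inside the range, or whether a phenyl ring with a single methyl group would give one too.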